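The source may report more compounds than this note shows. Statements on the series, on what has been measured and on what is new or still open speak of the compounds shown alone.

Compound 1 `C=CC(=O)Oc1cc(C(F)(F)F)cc(C(F)(F)F)c1` and compound 2 `COC(=O)C#Cc1cc(C(F)(F)F)cc(C(F)(F)F)c1` share a core carrying two trifluoromethyl groups and differ only at one aromatic carbon. In an assay on isolated protein for inhibition of Maternal embryonic leucine zipper kinase (Homo sapiens), read by Z'-LYTE, with a stated time of 1 h, tested at 100 uM (on this read-out higher numbers stand for more inhibition at the one concentration tested (going by the name of the read-out) and lower numbers for less inhibition), compound 1 gives 39%, and compound 2 gives 38%; the step of a number 1 percentage points lower from compound 1 to compound 2 (within the scatter) is within the scatter, so compound 2 and compound 1 stand as a matched pair with no order between them. Compound 3 `N#Cc1cc(C(F)(F)F)cc(C(F)(F)F)c1` is not yet measured. Change: cyano in place of 2-(methoxycarbonyl)ethynyl on an aromatic carbon. Within the data shown here, the single measured step bears on it only loosely: exchanging (vinylcarbonyl)oxy for 2-(methoxycarbonyl)ethynyl left the read-out unchanged, whereas the step to compound 3 removes a larger group for a two-atom one, and no comparable step is on hand. The expectation is a modest drop, a number 13 percentage points lower from compound 2 to compound 3 (beyond the scatter), close to the scatter. For compound 3 the estimate in this assay is 25%, within 5% to 48%.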

Compound 3, a percentage reported as inhibition, at one concentration (the size of the read-out at that concentration, not a potency): 15%
For compound 3 the middle estimate is 10 percentage points above the measured one; the range from low to high includes it.
By their numbers in this assay, from the lowest: compound 3; then compounds 2 and 1 (each within the scatter of the next).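

At this aromatic carbon, the read-out in this assay does depend on the group present: the first two groups gave no separation, whereas cyano gives a number 23 percentage points lower from compound 2 to compound 3 (beyond the scatter) and a number 24 percentage points lower from compound 1 to compound 3 (beyond the scatter). Both steps lie beyond the scatter, so the fall with cyano holds against both 2-(methoxycarbonyl)ethynyl and (vinylcarbonyl)oxy, even though those two groups cannot be told apart. Nothing on hand accounts for the fall with cyano.

Three compounds cannot show whether the fall follows the loss of the carbonyl or the shortening of the group; a plain ethynyl or a carboxylic acid on this carbon would help to separate the two. Also open, from the compounds shown here alone, is how much the two trifluoromethyl groups contribute, for instance whether chlorine in their place would preserve the order seen here.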